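From a Protected Side Chain to a Bare One

The source may report more compounds than this note shows. Statements on the series, on what has been measured and on what is new or still open speak of the compounds shown alone.

Of the compounds shown here, three sharing one core have been measured in a functional assay on the whole organism (Tail, strain ICR) with Mus musculus as the target, in the tail flick test, with a stated time of 90 min, at a dose of 25 umol/kg by the oral route; on this read-out higher numbers stand for a stronger effect at the one dose given and lower numbers for a weaker effect. Compound 1 `O=C(CN(c1ncnc2c1ncn2C1CCCCO1)C1CC1)NCC(=O)OCc1ccccc1` gives 25.9%. Compound 2 `C[C@H](NC(=O)CN(c1ncnc2c1ncn2C1CCCCO1)C1CC1)C(=O)OCc1ccccc1` gives 32.1%, and compound 3 `CC(C)(C)OC(=O)NCCCC[C@H](NC(=O)CN(c1ncnc2c1ncn2C1CCCCO1)C1CC1)C(=O)OCc1ccccc1` gives 32.9%, the highest of the three numbers, though the others sit close to it: a number 0.8 percentage points higher from compound 2 to compound 3 (within the scatter) and a number 7 percentage points higher from compound 1 to compound 3 (within the scatter) are both within the scatter, as is a number 6.2 percentage points higher from compound 1 to compound 2 (within the scatter). Among the measured compounds shown here, no compound therefore stands apart from the rest on this read-out.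

Compound 4 `N=C(N)NCCC[C@H](NC(=O)CN(c1ncnc2c1ncn2C1CCCCO1)C1CC1)C(=O)OCc1ccccc1` has not yet been measured. Its difference from compound 3 is a group of 4 heavy atoms (1 carbon, 3 nitrogen; no ring) in place of a group of 9 heavy atoms (6 carbon, 1 nitrogen, 2 oxygen; no ring), on a saturated chain carbon, four bonds along the chain from an amide-type nitrogen and a carbonyl carbon. For the measured compounds named here, none of the measured steps touches this part of the molecule; each of them concerns the group on the saturated chain carbon bound to the amide-type nitrogen and the carbonyl carbon, and each lay within the scatter. What can be drawn on is only a flat picture of three numbers that do not separate from one another. Compound 4 is expected to show an estimated step of a number 2.9 percentage points lower from compound 3 to compound 4 (within the scatter), not beyond the scatter. The estimate for compound 4 in this assay is 30%, with a range from 14% to 48%.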

Compound 4, a percentage reported as activity, at one dose (the size of the read-out at that dose, not a potency): 61.6%
Beside the measured number, compound 4's estimate is 31.6 percentage points below it; the whole stated range lies below it.
By their numbers in this assay, from the lowest: compounds 1, 2 and 3 (each within the scatter of the next); then compound 4.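

In this assay, among the compounds shown here, the replacement of ((tert-butoxycarbonyl)amino)methyl by the group of 4 heavy atoms (1 carbon, 3 nitrogen; no ring), on a saturated chain carbon, four bonds along the chain from an amide-type nitrogen and a carbonyl carbon, gives a number 28.7 percentage points higher from compound 3 to compound 4 (beyond the scatter), the first step to leave the scatter. The same rise appears against the shorter side chains, with a number 29.5 percentage points higher from compound 2 to compound 4 (beyond the scatter) and a number 35.7 percentage points higher from compound 1 to compound 4 (beyond the scatter), whereas the long protected chain of compound 3 had stayed within the scatter of compounds 1 and 2, so among these four compounds what stands at the end of the chain counts for more than the presence of a long chain. No measurement shown here explains why this group raises the number.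

The compounds shown leave open whether a plain primary amine at this place would give a number near that of compound 4 or near that of compound 3, and whether the rise would hold on a longer chain ending in the same group. They also leave open whether it would survive a carboxylic acid in place of the ester.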